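A Larger Group on the Nitrogen Chain of Compound 3

The compounds below may be only part of what the source reports. "The series", "measured", "known", "first", "only" and "open" are said of these compounds alone.

Three measured compounds share one core and were tested in an assay on isolated protein for inhibition of Gonadotropin-releasing hormone receptor (Homo sapiens); a lower number here means a stronger inhibitor, a higher number a weaker inhibitor. Compound 1 `COc1ccccc1CSc1nc2cc(NC(=O)C3CC3)ccc2n1C(C)C` gives 2100 nM. Compound 2 `COc1ccc(C#N)cc1CSc1nc2cc(NC(=O)C3CC3)ccc2n1C(C)C` gives 570 nM. Compound 3 `CCn1c(SCc2cc([N+](=O)[O-])ccc2OC)nc2cc(NC(=O)NC(C)(C)C)ccc21` gives 42 nM, the lowest of the three numbers; compound 2 stands nearest to it and compound 1 furthest, and both gaps lie beyond the scatter. Among the measured compounds shown here, the only step between compounds that differ in a single place is a 3.7-fold lower number from compound 1 to compound 2 (0.57 log units; beyond the scatter), a change on an aromatic carbon, not on the chain attached to the ring nitrogen.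

Compound 4 `COc1ccc([N+](=O)[O-])cc1CSc1nc2cc(NC(=O)NC(C)(C)C)ccc2n1Cc1ccccn1` differs from compound 3 by pyridin-2-yl in place of methyl on a saturated chain carbon bound to an aromatic nitrogen. For the measured compounds named here, no two measured compounds differ only at this place, so no measured step bears on the change. Going by the values given here, the one step that exists, from hydrogen to cyano, concerns another part of the molecule and gives no guidance here. With nothing to lean on, the plain expectation is a number close to that of compound 3, held with wide uncertainty in either direction.

For compound 4 the estimated value is 40 nM, with a range from 10 nM to 160 nM. The step this estimate implies, a 1.1-fold lower number from compound 3 to compound 4 (0.02 log units; within the scatter), is expected to remain within the scatter.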

Compound 4, half-maximal inhibitory concentration: 43 nM
Compound 4: middle estimate off by 1.1-fold (0.03 log units), on the low side; low and high end bracket the measured number.
By their numbers in this assay, from the lowest: compounds 3 and 4 (each within the scatter of the next); then compound 2; then compound 1.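

In this assay, among the compounds shown here, the exchange of methyl for pyridin-2-yl on a saturated chain carbon bound to an aromatic nitrogen gives a 1.0-fold higher number from compound 3 to compound 4 (0.01 log units; within the scatter), the first measured step at this place, and it lies within the scatter. The group entering brings 6 heavy atoms, one six-membered aromatic ring and 1 hydrogen-bond acceptor in place of 1 heavy atom, so in this pair, a much larger group at this place leaves the number indistinguishable from that of compound 3. Nothing measured here explains why the two groups read alike.

This is a single pair, so it cannot show whether a similar result is specific to pyridin-2-yl or would extend to other groups at this place, such as phenyl, an amine or a carboxylic acid at the end of the chain, or a longer chain between the ring and the aromatic nitrogen. It also leaves open whether the same exchange would read alike with the cyclopropyl amide of compound 1 and compound 2 in place of the tert-butyl urea of compound 3.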